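The source may report more compounds than this note shows. Statements on the series, on what has been measured and on what is new or still open speak of the compounds shown alone.

Compounds measured so far:
- compound 1, `COc1cc(NC(=O)Nc2cc(Nc3ccc(C(C)(C)C)cc3)ncn2)cc(OC)c1`: 17.5%
- compound 2, `Cc1ccc(Nc2cc(NC(=O)Nc3c(Cl)cccc3Cl)ncn2)cc1C`: 47.5%
- compound 3, `Cc1cc(F)cc(Nc2cc(NC(=O)Nc3c(Cl)cccc3Cl)ncn2)c1`: 60.5%

In a functional assay on NCI-H520 cells (Homo sapiens) for inhibition, read by MTT assay, with a stated time of 48 h, tested at 10 uM (on this read-out lower numbers stand for less inhibition and higher numbers for more inhibition at the one concentration tested (going by the name of the read-out)), compound 1 gives 17.5%, the lowest of the three numbers; compound 2 gives 47.5% and compound 3 gives 60.5%, both of them higher than compound 1 by more than the scatter. Among the compounds with values here, the only one-place step among the measured compounds is a number 13 percentage points higher from compound 2 to compound 3 (beyond the scatter), in which a fluorine replaces one of two methyl groups on the aryl group that sits on the ring nitrogen.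

Compound 4, `COc1cc(NC(=O)Nc2cc(Nc3ccc(C)c(F)c3)ncn2)cc(OC)c1`, is compound 1 with 3-fluoro-4-methylphenyl in place of 4-(tert-butyl)phenyl on a nitrogen on an aromatic ring. Within the data shown here, this change bears some likeness to the measured step: the entering group, like that of compound 3, carries a fluorine and a methyl group, while the leaving tert-butyl group has no counterpart among compounds 2 and 3. The shared core differs from that of compounds 2 and 3 in the other urea substituent, so the step transfers only loosely. A moderate rise is expected for compound 4, a number 17.5 percentage points higher from compound 1 to compound 4 (beyond the scatter), leaving compound 4 at an estimated 35% with a range of 15% to 55%.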

Compound 4, a percentage reported as inhibition, at one concentration (the size of the read-out at that concentration, not a potency): 30.6%
For compound 4 the middle estimate is 4.4 percentage points above the measured one, within the range that was stated.
By their numbers in this assay, from the lowest: compound 1; then compound 4; then compound 2; then compound 3.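

In this assay, putting 3-fluoro-4-methylphenyl in place of 4-(tert-butyl)phenyl on the nitrogen gives a number 13.1 percentage points higher from compound 1 to compound 4 (beyond the scatter). The earlier step at this nitrogen came only with the urea substituent of compound 2 and compound 3, so this result shows that the read-out also responds to a change of aryl group with the shared core of compound 1. No measurement available here explains the rise.

Because the group that enters differs from the one that leaves in several ways at once, the compounds shown cannot separate the part played by the fluorine, the methyl group and the loss of the tert-butyl group. As far as these compounds go, how a plain phenyl, or an aryl group carrying an amine or a carboxylic acid, would read on this nitrogen also remains open.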